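This account rests on a few compounds, and the source may have more. Where it says the series, first, only, none or still open, it means among the compounds named here.

Measured so far in an assay on isolated protein for inhibition of Matrilysin (Homo sapiens), read by fluorescence, with a stated time of 15 min; on this read-out higher numbers stand for weaker inhibition and lower numbers for stronger inhibition:
compound 1 `CC(C)C[C@H](NC(=O)CNC(=O)CC[C@H](NS(=O)(=O)c1ccc(Cl)c(C(F)(F)F)c1)C(=O)O)C(=O)N[C@H](C(=O)N[C@@H](C)C(N)=O)C(C)C` gives 16 nM
compound 2 `CSCC[C@H](NC(=O)[C@H](CC(C)C)NC(=O)[C@H](C)NC(=O)C[C@H](NS(=O)(=O)c1ccc(Cl)c(C(F)(F)F)c1)C(=O)O)C(N)=O` gives 4700 nM
compound 3 `CSCC[C@H](NC(=O)[C@H](CC(C)C)NC(=O)CNC(=O)CC[C@H](NS(=O)(=O)c1ccc(Cl)c(C(F)(F)F)c1)C(=O)O)C(N)=O` gives 120 nM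

Compound 1 stands at the lowest number of the three in this assay; compound 3 is nearest and compound 2 furthest, both beyond the scatter, so compound 1 is the strongest inhibitor among those measured. The next compound, compound 4 `CC(C)C[C@H](NC(=O)CNC(=O)CC[C@H](NS(=O)(=O)c1ccc(Cl)c(C(F)(F)F)c1)C(=O)O)C(=O)N[C@H](C(=O)N1CCC[C@H]1C(N)=O)C(C)C`, keeps the core of compound 1 and differs only at the chain end: 2-carbamoylpyrrolidin-1-yl in place of (1-carbamoylethyl)amino on a carbonyl carbon. One hydrogen-bond donor is given up in the exchange while the carbamoyl end is retained.

Among the measured compounds shown here, no measured step changes this position alone. For the measured compounds named here, the only single-place step, a 7.5-fold higher number from compound 1 to compound 3 (0.88 log units; beyond the scatter), removes the whole 1-((1-carbamoylethyl)carbamoyl)-2-methylpropyl unit and so speaks to the worth of that tail as such, not to a swap within it. Compound 2 and compound 3 differ in more than one place and their values give no direct guidance here. With the tail length kept and only its last unit closed into a ring, a small step is expected, at most a modest loss: a 1.6-fold higher number from compound 1 to compound 4 (0.19 log units; within the scatter) is the expected outcome. Compound 4 is therefore expected to give about 25 nM in this assay, within 8 nM to 80 nM.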

Compound 4, half-maximal inhibitory concentration: 19 nM
Estimate against measurement, compound 4: 1.3-fold (0.12 log units) above; measured number inside the range.
By their numbers in this assay, from the lowest: compounds 1 and 4 (each within the scatter of the next); then compound 3; then compound 2.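

In this assay, among the compounds shown here, the exchange of (1-carbamoylethyl)amino for 2-carbamoylpyrrolidin-1-yl on a carbonyl carbon gives a 1.2-fold higher number from compound 1 to compound 4 (0.07 log units; within the scatter) and is the first change read within the tail, whereas a 7.5-fold higher number from compound 1 to compound 3 (0.88 log units; beyond the scatter) reports the replacement of the whole 1-((1-carbamoylethyl)carbamoyl)-2-methylpropyl unit. At this position, a group with 8 heavy atoms and one five-membered non-aromatic ring, carrying 1 hydrogen-bond donor, can therefore take the place of a group with 6 heavy atoms, no ring and 2 hydrogen-bond donors without a change beyond the scatter, so the low number of compound 1 does not depend on the open-chain form of this end. No independent measurement is available to explain this result.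

The compounds shown leave open how much the carbamoyl end itself contributes, since it is present in both compound 1 and compound 4, and a carboxylic acid or a nitrile in its place would address that. They also leave open how far the ring can change at this position, for example with a six-membered piperidine in place of the pyrrolidine.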